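Pyrrolidin-1-yl to imidazol-1-yl swap on two cores

The source may report more compounds than this note shows. Statements on the series, on what has been measured and on what is new or still open speak of the compounds shown alone.

Measured compounds:
compound 1 `COC(=O)N(C)CC#CCN1CCCC1`: 1.4 mg/kg
compound 2 `COC(=O)N(C)CC#CCn1ccnc1`: 2 mg/kg
compound 3 `Cn1ccn(CC#CCN2CCCC2)c1=O`: 3.7 mg/kg

All three values come from a functional assay on the whole organism for agonist activity, with Mus musculus as the target; a lower number here means that less compound is needed, a higher number that more compound is needed for the effect. Compound 2 differs from compound 1 by 1H-imidazol-1-yl in place of pyrrolidin-1-yl on a saturated chain carbon bound to a triple-bonded carbon, and the resulting step is a 1.4-fold higher number from compound 1 to compound 2 (0.15 log units; within the scatter). Compound 3 sits on a different core; how the core of compound 3 differs from that of compound 1 is not broken down here. Compound 4 `Cn1ccn(CC#CCn2ccnc2)c1=O` has not been measured. It differs from compound 3 by 1H-imidazol-1-yl in place of pyrrolidin-1-yl on a saturated chain carbon bound to a triple-bonded carbon, which is the same change, at the same place, as from compound 1 to compound 2. The step in this assay is expected to be of similar size, a 1.4-fold higher number from compound 3 to compound 4 (0.13 log units; within the scatter), because a 1.4-fold higher number from compound 1 to compound 2 (0.15 log units; within the scatter) lay within the scatter. Compound 4 is therefore estimated at 5 mg/kg, with a likely range from 2.5 mg/kg to 10 mg/kg.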

Compound 4, dose for half-maximal effect: 4.5 mg/kg
Compound 4: middle estimate off by 1.1-fold (0.05 log units), on the high side, and the stated range covers the measured number.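

The new step, a 1.2-fold higher number from compound 3 to compound 4 (0.09 log units; within the scatter), fits the earlier result. In this assay, the exchange of pyrrolidin-1-yl for 1H-imidazol-1-yl reads the same on both cores: the same change on two cores in this assay, a 1.4-fold higher number (0.15 log units; within the scatter) from compound 1 to compound 2 and a 1.2-fold higher number (0.09 log units; within the scatter) from compound 3 to compound 4, 1.2-fold (0.07 log units) apart, within the scatter of two such steps

Among these compounds, this shows only that the change stays small on these two cores; since neither step leaves the scatter, it does not show that the exchange has a real effect of its own, nor that a larger effect would carry over, and two cores cannot establish a rule for the series.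

Open, on these data alone, is whether the same holds on a third core. Also open, as far as these compounds go, is how a piperidine ring, an open-chain dimethylamino group or a longer chain would read on the saturated chain carbon bound to a triple-bonded carbon.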